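The source may hold more compounds than are shown below. What is called first, only, known or untested is meant among the compounds shown, and "the series" means these compounds.

Measured so far:
compound 1, `CCOC(=O)C1=C(C)NC(COC)=C(C(=O)OC)C1c1ccccc1[N+](=O)[O-]`, 1760 nM
compound 2, `CCOC(=O)C1=C(C)NC(C)=C(C(=O)OC=O)C1c1cccc([N+](=O)[O-])c1`, 33300 nM
compound 3, `COC(=O)C1=C(C)NC(C)=C(C(=O)OCc2cc([N+](=O)[O-])cc([N+](=O)[O-])c2)C1c1cccc([N+](=O)[O-])c1`, 55 nM

In a functional assay on HEK293 cells for antagonist activity at Voltage-dependent L-type calcium channel subunit alpha-1C (Oryctolagus cuniculus), read by FLIPR (on this read-out lower numbers stand for stronger inhibition and higher numbers for weaker inhibition), compound 3 stands lowest of the three numbers. Compound 1 lies nearest to it and compound 2 furthest, and both gaps are beyond the scatter, so compound 3 is the strongest inhibitor among the measured compounds. For the measured compounds named here, no pair of these differs in one place only, so no single step is known.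

Compound 4, `COC(=O)C1=C(C)NC(C)=C(C(=O)OCCCCc2ccc(OC)cc2)C1c1cccc([N+](=O)[O-])c1`, is not yet measured. It differs from compound 3 in one place: 3-(4-methoxyphenyl)propyl in place of 3,5-dinitrophenyl on a saturated chain carbon bound to an oxygen next to a carbonyl group. Going by the values given here, with no comparable step among the measured compounds, the expectation rests on compound 3 alone, whose value in this assay is 55 nM. For compound 4 a modest move toward weaker inhibition is expected, a step of a 2.7-fold higher number from compound 3 to compound 4 (0.44 log units; beyond the scatter), giving an estimate of 150 nM within a range from 40 nM to 600 nM.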

Compound 4, half-maximal inhibitory concentration: 17 nM
Compound 4: the middle estimate sits 8.8-fold (0.95 log units) above what was measured; measured number below the stated range.
By their numbers in this assay, from the lowest: compound 4; then compound 3; then compound 1; then compound 2.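

At this position in this assay, 3-(4-methoxyphenyl)propyl in place of 3,5-dinitrophenyl gives a 3.2-fold lower number from compound 3 to compound 4 (0.51 log units; beyond the scatter). Strong inhibition here therefore does not depend on the 3,5-dinitrophenyl group, and a group with one hydrogen-bond acceptor instead of four, and with no nitrogen, is accepted on the same saturated chain carbon. No measurement at hand explains this step. The compounds shown leave open whether the methoxy group or the propyl chain contributes more to the step. Going by these compounds, how an amine or a carboxylic acid in this place would compare also stays open.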